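Swapping the nitrophenyl arm for a chlorofluorophenyl arm

This account rests on a few compounds, and the source may have more. Where it says the series, first, only, none or still open, it means among the compounds named here.

The series shares one core, seen in compound 1 `O=C(/C=C/c1ccc([N+](=O)[O-])cc1)Nc1cc2c(Nc3ccc(F)c(Cl)c3)ncnc2cc1O[C@H]1CCOC1`, which in a functional assay on HeLa cells (Homo sapiens) for cytotoxicity, read by MTT assay, with a stated time of 72 h (a higher number here means a weaker inhibitor, a lower number a stronger inhibitor), gives 27400 nM. Compound 2 `O=C(/C=C/c1cccc(Cl)c1Cl)Nc1cc2c(Nc3ccc(F)c(Cl)c3)ncnc2cc1O[C@H]1CCOC1` gives 30500 nM in this assay, and the step of a 1.1-fold higher number from compound 1 to compound 2 (0.05 log units; within the scatter) falls within the scatter. Compound 1 thus stands at the lowest of the two numbers, with compound 2 its nearest neighbour. Compound 3 `N#Cc1ccc(/C=C/C(=O)Nc2cc3c(Nc4ccc(F)c(Cl)c4)ncnc3cc2O[C@H]2CCOC2)cc1` is recorded in this assay only as "not determined" (no result reported), so no number is available for it. Compound 4 `O=C(/C=C/c1ccc(F)cc1Cl)Nc1cc2c(Nc3ccc(F)c(Cl)c3)ncnc2cc1O[C@H]1CCOC1` differs from compound 1 as follows: 2-chloro-4-fluorophenyl in place of 4-nitrophenyl on a double-bonded chain carbon bound to a double-bonded chain carbon. Going by the values given here, the one step that bears on this change, from compound 1 to compound 2, also replaced 4-nitrophenyl with a halogenated phenyl and moved the number only within the scatter, so no step beyond the scatter is expected here. Compound 4 is therefore expected to give 28000 nM, between 10000 nM and 80000 nM, a step of a 1.0-fold higher number from compound 1 to compound 4 (0.01 log units; within the scatter).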

Compound 4, half-maximal inhibitory concentration: 37500 nM
Beside the measured number, compound 4's estimate is 1.3-fold (0.13 log units) below it; low and high end bracket the measured number.
By their numbers in this assay, from the lowest: compounds 1, 2 and 4 (each within the scatter of the next).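

Putting 2-chloro-4-fluorophenyl in place of 4-nitrophenyl gives a 1.4-fold higher number from compound 1 to compound 4 (0.14 log units; within the scatter) in this assay, and putting it in place of 2,3-dichlorophenyl gives a 1.2-fold higher number from compound 2 to compound 4 (0.09 log units; within the scatter). Going by these compounds alone, three differently substituted phenyl groups at this place now stand within the scatter of one another, which the single earlier step could not show. Nothing available explains this flatness. The compounds shown leave open whether the numbers stay this close with an unsubstituted phenyl, or with a non-aromatic group such as a morpholine or a carboxylic acid at this place.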